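The source may report more compounds than this note shows. Statements on the series, on what has been measured and on what is new or still open speak of the compounds shown alone.

Compound 1 `Cc1nc(-c2ccccc2NCC2=NCCN2)n(C)n1` in an in vitro functional assay on cells (Fibroblast) for agonist activity at Alpha-1D adrenergic receptor (Homo sapiens) (on this read-out lower numbers stand for an effect already at smaller amounts and higher numbers for an effect only at larger amounts of compound), gives < 5020 nM, a limit of the assay.
Compound 2 `CCn1cccc1-c1ccccc1NCC1=NCCN1` in this assay gives < 100000 nM, also a limit.
Compound 3 `CCn1ccc(-c2ccccc2NCC2=NCCN2)n1` in this assay gives < 100000 nM, again a limit.

Compound 2 thus stands at a limit and not at a number. Of the three values shown, two sit at the limit of < 100000 nM in this assay, at which 2 of the 3 values shown sit, and one at the limit of < 5020 nM in this assay, at which 1 of the 3 values shown sits, so no measured step separates any pair of these compounds. Compound 4 `Cn1cccc1-c1ccccc1NCC1=NCCN1` differs from compound 2 by hydrogen in place of methyl on a saturated chain carbon bound to an aromatic nitrogen. For the measured compounds named here, with no measured step to lean on, a change in this assay beyond the usual scatter is not expected in either direction. The expected step that the limit leaves unreadable from compound 2 to compound 4 is therefore none beyond the scatter. Compound 4 is estimated at 30000 nM, within 3000 nM to 100000 nM, and may well again be reported only as a limit.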

Compound 4, half-maximal effective concentration: 251 nM
Estimate against measurement, compound 4: 120-fold (2.08 log units) above, outside the stated range (below it).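

In this assay, for the compounds shown here, compound 2 gives < 100000 nM, which is a limit, so no step from it to compound 4 can be read. The compounds shown leave open how large the change from ethyl to methyl really is.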